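The source may report more compounds than this note shows. Statements on the series, on what has been measured and on what is new or still open speak of the compounds shown alone.

Measured compounds:
Compound 1, `CCCCc1cn(C[C@H](O)[C@H]2OC(=O)C(OCc3ccccc3)=C2OCc2ccccc2)nn1`: in a functional assay on HepG2 cells (Homo sapiens) for antiproliferative activity, read by MTT assay, with a stated time of 72 h (a lower number here means a stronger inhibitor, a higher number a weaker inhibitor), compound 1 gives 32800 nM.
Compound 2, `COc1ccccc1-c1cn(C[C@H](O)[C@H]2OC(=O)C(OCc3ccccc3)=C2OCc2ccccc2)nn1`: in this assay compound 2 gives > 100000 nM, which is a limit of the assay and not a number.

Compound 2 thus sits at the weak end of the two values shown; what is known of it is the limit of > 100000 nM in this assay, at which 1 of the 2 values shown sits. Going by the values given here, the one measured step, an at least 3.0-fold higher number from compound 1 to compound 2 (0.48 log units; beyond the scatter), concerns the same aromatic carbon but a different pair of groups, so it bears on compound 3 only loosely. Compound 3, `O=C1O[C@H]([C@@H](O)Cn2cc(CNS(=O)(=O)c3ccc(F)cc3)nn2)C(OCc2ccccc2)=C1OCc1ccccc1`, is not yet measured. It differs from compound 2 by (((4-fluorophenyl)sulfonyl)amino)methyl in place of 2-methoxyphenyl on an aromatic carbon. With compound 2 only a limit and no measured exchange of this new group, the direction of the step to compound 3 cannot be fixed from the numbers shown; the step of an at least 3.0-fold higher number from compound 1 to compound 2 (0.48 log units; beyond the scatter) does show that a change at this carbon can move the value beyond the scatter in this assay. The expected value for compound 3 is 60000 nM, within 15000 nM to 200000 nM, an expected step of an at least 1.6-fold lower number from compound 2 to compound 3 (0.22 log units; that floor lies within the scatter). A fair chance remains that compound 3 again returns only a limit.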

Compound 3, half-maximal inhibitory concentration: 18300 nM
For compound 3 the middle estimate is 3.3-fold (0.52 log units) above the measured one; measured number inside the range.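

Putting (((4-fluorophenyl)sulfonyl)amino)methyl in place of 2-methoxyphenyl gives an at least 5.4-fold lower number from compound 2 to compound 3 (0.73 log units; beyond the scatter), so this aromatic carbon, where the earlier pair showed only a move toward a higher number, can also support a move toward a lower one. The size of that step is only a floor, because compound 2 is known only as a limit of the assay and not as a number: the limit of > 100000 nM in this assay, at which 1 of the 3 values shown sits.

Swapping ((4-fluorophenyl)sulfonyl)amino for propyl on the saturated chain carbon gives a 1.8-fold lower number from compound 1 to compound 3 (0.25 log units; within the scatter), so the butyl chain and the much larger sulfonyl-bearing chain cannot be told apart in this assay, and the aromatic ring that compound 3 carries in this chain does not by itself place it with compound 2.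

The compounds shown do not separate the contribution of the sulfonyl amino unit from that of the 4-fluorophenyl group. From the compounds shown here alone, how a primary amine, a carboxylic acid or a longer alkyl chain on this aromatic carbon would read in this assay also remains open.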